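Replacing 3-bromo-2-hydroxypropoxy with chloromethyl

The compounds below may be only part of what the source reports. "The series", "measured", "known", "first", "only" and "open" are said of these compounds alone.

Measured so far in an ADME assay for pharmacokinetics (a lower number here means that the compound disappears faster, a higher number that the compound lasts longer), for three compounds
Compound 1 `CC[C@H](c1ccc(O)cc1)[C@@H](CC)c1ccc(OCC(O)CBr)cc1` gives 0.5 h
Compound 2 `CC[C@H](c1ccc(O)cc1)[C@@H](CC)c1ccc(OCC(O)CCl)cc1` gives 0.5 h
Compound 3 `CC[C@H](c1ccc(O)cc1)[C@@H](CC)c1ccc(OCC2CO2)cc1` gives 4 h

Compound 1 stands level with compound 2, together the lowest of the three numbers. Compound 4 `CC[C@H](c1ccc(O)cc1)[C@@H](CC)c1ccc(CCl)cc1` has not been measured. It carries chloromethyl in place of 3-bromo-2-hydroxypropoxy on an aromatic carbon in the shared core. Three measured steps offer a loose guide. Swapping only the halogen gave no change at the digits printed from compound 1 to compound 2 (within the scatter) for the pair, while oxiran-2-yl in place of the open chain gave an 8.0-fold higher number from compound 1 to compound 3 (0.90 log units; beyond the scatter) and an 8.0-fold higher number from compound 2 to compound 3 (0.90 log units; beyond the scatter) in turn. None of these steps removes the whole group. The expected change is therefore small, with a 1.6-fold higher number from compound 1 to compound 4 (0.20 log units; within the scatter) as the estimate in this assay for this step. For compound 4 the expected half-life is 0.8 h with an estimated range from 0.25 h to 3 h for now.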

Compound 4, half-life: 1.3 h
Beside the measured number, compound 4's estimate is 1.6-fold (0.21 log units) below it; the range from low to high includes it.
By their numbers in this assay, from the lowest: compounds 1 and 2 (each within the scatter of the next); then compound 4; then compound 3.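

In this assay the chloromethyl group gives a 2.6-fold higher number from compound 1 to compound 4 (0.41 log units; beyond the scatter) and a 2.6-fold higher number from compound 2 to compound 4 (0.41 log units; beyond the scatter) when it replaces the open hydroxy chains, so the half-life moves when the whole chain goes, not only when it closes into an oxirane ring. Replacing (oxiran-2-yl)methoxy gives a 3.1-fold lower number from compound 3 to compound 4 (0.49 log units; beyond the scatter) and leaves chloromethyl between the two kinds of chain. Nothing available here explains these shifts.

Open, as far as these compounds go, is whether the chlorine itself matters, which a plain methyl or a hydroxymethyl on this aromatic carbon would help to show. Also open, from the compounds shown here alone, is how an amine or a carboxylic acid would fare there.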